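Adding one methyl to compound 2

The source may hold more compounds than are shown below. What is called first, only, known or untested is meant among the compounds shown, and "the series" means these compounds.

Measured so far:
- compound 1 `Cc1cc2nc(-c3cn(-c4ccccc4)nc3-c3ccc(Cl)cc3)[nH]c2cc1C`: 13000 nM
- compound 2 `COc1ccc(-c2nn(-c3ccccc3)cc2-c2nc3cc(C)ccc3[nH]2)cc1`: 6610 nM

Both values come from a functional assay on MCF7 cells (Homo sapiens) for antiproliferative activity, read by MTT assay, with a stated time of 48 h; on this read-out higher numbers stand for weaker inhibition and lower numbers for stronger inhibition. In this read-out, compound 2 stands at 6610 nM and compound 1 at 13000 nM. For the measured compounds named here, these two values lie within the usual scatter of each other, so they give no ranking, and the series has no measured step between compounds that differ in one place.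

Next is compound 3 `COc1ccc(-c2nn(-c3ccccc3)cc2-c2nc3cc(C)c(C)cc3[nH]2)cc1`, which differs from compound 2 by one change: methyl in place of hydrogen on an aromatic carbon. Going by the values given here, no measured pair isolates this change, so its effect in this assay cannot be read from the data, and no direction is favoured. The expectation is therefore a step no larger than the scatter, anchored on compound 2 at 6610 nM. The estimated step is small, a 1.1-fold lower number from compound 2 to compound 3 (0.04 log units; within the scatter), and is expected to stay within the scatter. For compound 3 the expected value is 6000 nM, with an estimated range of 2500 nM to 14000 nM.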

Compound 3, half-maximal inhibitory concentration: 12800 nM
Compound 3: the middle estimate sits 2.1-fold (0.33 log units) below what was measured, within the range that was stated.
By their numbers in this assay, from the lowest: compounds 2, 3 and 1 (each within the scatter of the next).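

In this assay the series now has its first measured steps between compounds that differ in one place. Methyl in place of hydrogen on an aromatic carbon, at the place ortho to a methyl group, gives a step that lies within the scatter (a 1.9-fold higher number from compound 2 to compound 3 (0.29 log units; within the scatter)), so no effect of this methyl on antiproliferative activity can be resolved at this position. Methoxy in place of chloro on an aromatic carbon also gives a step within the scatter (a 1.0-fold lower number from compound 1 to compound 3 (0.01 log units; within the scatter)), so this exchange does not separate its pair either, and nothing measured on these compounds offers an explanation for either step.

The compounds shown leave open whether any group other than methyl at this position, such as an amine or a carboxylic acid, would give a step beyond the scatter. They also leave open whether the aromatic carbon that carries methoxy in compound 3 would respond to something other than methoxy or chloro, such as a longer alkoxy chain or a dimethylamino group.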